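The compounds below may be only part of what the source reports. "The series", "measured", "known", "first", "only" and "open" are said of these compounds alone.

Notes on the series: in an ADME assay on HepG2 2.2.15 cells (Homo sapiens) for cytotoxicity, read by luminescence, with a stated time of 3 days (a lower number here means that less compound is tolerated, a higher number that more compound is tolerated), compound 1 `O=C(Nc1ccc(F)c(Cl)c1)c1ccc(F)c(S(=O)(=O)N2CCCCCC(O)C2)c1` gives 11000 nM and compound 2 `O=C(Nc1ccc(F)c(Cl)c1)c1ccc(F)c(S(=O)(=O)N2CCCCC(O)C2)c1` gives 15000 nM, so compound 2 stands level with compound 1 within the scatter. Compound 3 `CC(O)C1CCCCN(S(=O)(=O)c2cc(C(=O)Nc3ccc(F)c(Cl)c3)ccc2F)C1` differs from compound 2 by 1-hydroxyethyl in place of hydroxy on a saturated ring carbon, with 1-hydroxyethyl in place of hydroxy on a saturated ring carbon. For the measured compounds named here, the one measured step, a 1.4-fold higher number from compound 1 to compound 2 (0.13 log units; within the scatter), alters ring size, not this group, so it bears only indirectly. No step beyond the scatter is expected in this assay. The expected change is a 1.3-fold lower number from compound 2 to compound 3 (0.10 log units; within the scatter). For compound 3 the estimated value is 12000 nM, with an expected range of 6000 nM to 25000 nM.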

Compound 3, half-maximal cytotoxic concentration: 2600 nM
Compound 3: the middle estimate sits 4.6-fold (0.66 log units) above what was measured; measured number below the stated range.
By their numbers in this assay, from the lowest: compound 3; then compounds 1 and 2 (each within the scatter of the next).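

In this assay, 1-hydroxyethyl in place of hydroxy on a saturated ring carbon, two ring bonds from the ring nitrogen, gives a 5.8-fold lower number from compound 2 to compound 3 (0.76 log units; beyond the scatter), so this position responds to the change, whereas the ring-size step stayed within the scatter. The step of a 4.2-fold lower number from compound 1 to compound 3 (0.63 log units; beyond the scatter), which also spans a ring-size difference, points the same way. Nothing available explains this drop.

From the compounds shown here alone, what an amine, a methoxy group or a longer chain on this ring carbon would give remains open. So does whether 1-hydroxyethyl on the eight-membered ring gives a step of similar size.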